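Fluorine moved around the aryl ring of an acrylamide thiazolidine

This account rests on a few compounds, and the source may have more. Where it says the series, first, only, none or still open, it means among the compounds named here.

Measured so far:
Compound 1, `C#CC(=O)N1C(c2cccc(F)c2)SC[C@@H]1C(=O)OCC`: 1700 nM
Compound 2, `C#CC(=O)N1C(C(C)CCC)SC[C@@H]1C(=O)OCC`: 500 nM
Compound 3, `C#CC(=O)N1C(C(C)(C)C)SC[C@@H]1C(=O)OCC`: 900 nM

In a functional assay on MV cells (Homo sapiens) for inhibition, read by sulforhodamine B assay (on this read-out lower numbers stand for stronger inhibition and higher numbers for weaker inhibition), compound 1 gives 1700 nM. Among the three measured compounds only the step to compound 2 carries it beyond the scatter, a 3.4-fold lower number from compound 1 to compound 2 (0.53 log units; beyond the scatter); the step to compound 3, a 1.9-fold lower number from compound 1 to compound 3 (0.28 log units; within the scatter), stays within it, as does a 1.8-fold higher number from compound 2 to compound 3 (0.26 log units; within the scatter).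

Compound 4, `C#CC(=O)N1C(c2ccc(F)cc2)SC[C@@H]1C(=O)OCC`, is compound 1 with one change: 4-fluorophenyl in place of 3-fluorophenyl on a saturated ring carbon. For the measured compounds named here, no measured step bears directly on this change. Both known steps from compound 1 replace the 3-fluorophenyl group with an alkyl group, and neither says anything about moving the fluorine from one position on the aryl ring to another. Going by the values given here, with no step of that kind to lean on, compound 4 is expected to sit close to compound 1 in this assay, with a step no larger than the scatter, no change at the digits printed from compound 1 to compound 4 (within the scatter).

Compound 4 is therefore estimated at 1700 nM, with a range from 700 nM to 4000 nM.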

Compound 4, half-maximal inhibitory concentration: 400 nM
Compound 4: the middle estimate sits 4.3-fold (0.63 log units) above what was measured; the whole stated range lies above it.
By their numbers in this assay, from the lowest: compounds 4, 2, 3 and 1 (each within the scatter of the next, the first and the last beyond it).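

In this assay, the place of the fluorine on the aryl ring matters: the move gives a 4.3-fold lower number from compound 1 to compound 4 (0.63 log units; beyond the scatter), so two groups with the same atoms are not interchangeable on this saturated ring carbon. An aryl group here can also match the better alkyl group, since a 1.3-fold lower number from compound 2 to compound 4 (0.10 log units; within the scatter) stays within the scatter, while a 2.3-fold lower number from compound 3 to compound 4 (0.35 log units; beyond the scatter) goes beyond it. Nothing available explains why moving the fluorine changes the number.

The compounds shown leave open how a phenyl group without fluorine, a pyridyl group or a 4-methoxyphenyl group would read on this ring carbon. They also leave open whether the difference between the two fluorophenyl groups would persist with a carboxylic acid in place of the ethoxycarbonyl group.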